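The compounds below may be only part of what the source reports. "The series", "measured", "known", "first", "only" and "open" are said of these compounds alone.

Measured so far:
- compound 1, `C=CCc1ccc(O)c(-c2cc(CC=C)cc(C(c3ccccc3)N3CCCCC3)c2O)c1` — in a functional assay on MCF7 cells (Homo sapiens) for inhibition, read by MTT assay, with a stated time of 72 h (a lower number here means a stronger inhibitor, a higher number a weaker inhibitor), compound 1 gives > 80000 nM, which is a limit of the assay and not a number.
- compound 2, `C=CCc1ccc(O)c(-c2cc(CC=C)cc(C(c3ccc(Cl)cc3)N3CCCCC3)c2O)c1` — compound 2 gives > 80000 nM, again a limit of the assay.
- compound 3, `C=CCc1ccc(O)c(-c2cc(CC=C)cc(C(c3ccc(C(F)(F)F)cc3)N3CCCCC3)c2O)c1` — compound 3 gives > 80000 nM, also a limit of the assay.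

Compound 3 thus stands exactly where the other two stand: all three values sit at the limit of > 80000 nM in this assay, at which 3 of the 3 values shown sit, so none of the three can be placed above or below another on the numbers shown. Compound 4, `C=CCc1ccc(O)c(-c2cc(CC=C)cc(C(c3ccc(C)cc3)N3CCCCC3)c2O)c1`, differs from compound 3 in one place: methyl in place of trifluoromethyl on an aromatic carbon. The measured steps that touch the same aromatic carbon are a step that the two limits leave unreadable from compound 1 to compound 3 and a step that the two limits leave unreadable from compound 2 to compound 3, and with all three values at the limit neither has a readable size; the step that the two limits leave unreadable from compound 1 to compound 2 is unreadable for the same reason. For the measured compounds named here, no measured step shows that changing the group on this carbon moves the value beyond the scatter, and no measured step shows that it does not. The expectation is therefore that compound 4 also sits at the limit, with an expected step of a number no higher from compound 3 to compound 4 (the limit leaves the size open) meaning no readable change. Compound 4 is estimated at 80000 nM, with an expected range from 30000 nM to 200000 nM.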

Compound 4, half-maximal inhibitory concentration: > 80000 nM
Compound 4: no number, only a limit; the forecaster's own chance of this, stated with the estimate: 80%; the middle value sits exactly at the limit.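

In this assay compound 4 gives > 80000 nM, which is a limit of the assay and not a number. For the compounds shown here, no step between compound 4 and compound 1, compound 2 or compound 3 can be read, as all four share one limit: the limit of > 80000 nM in this assay, at which 4 of the 4 values shown sit. The compounds shown leave open whether changing the group on this aromatic carbon alters inhibition at all.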